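The compounds below may be only part of what the source reports. "The series", "measured", "known", "first", "only" and "open" are said of these compounds alone.

In a functional assay on HeLa cells (Homo sapiens) for inhibition, read by MTT assay, with a stated time of 72 h (a lower number here means a stronger inhibitor, a higher number a weaker inhibitor), compound 3 (`COc1cc(NC(C)CCCNC(=O)Nc2ccc(C(F)(F)F)cc2)c2ncccc2c1`) gives 8300 nM. Compound 2 (`COc1cc(NC(C)CCCNC(=O)NNC(=O)Nc2ccc(C(F)(F)F)cc2)c2ncccc2c1`) gives 15000 nM, and these two values lie within the scatter of each other. Compound 1 (`COc1cc(NC(C)CCCNC(=O)NNC(=O)Nc2ccc(F)cc2)c2ncccc2c1`) gives >= 250000 nM, which is a limit of the assay and not a number. Compound 4 (`COc1cc(NC(C)CCCNC(=O)NNC(=O)Nc2ccc(O)cc2)c2ncccc2c1`) has not yet been measured. It differs from compound 3 on an amide-type nitrogen, with ((4-hydroxyphenyl)carbamoyl)amino in place of 4-(trifluoromethyl)phenyl on an amide-type nitrogen.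

Among the compounds with values here, two measured steps bear on this change. The step of an at least 30-fold lower number from compound 1 to compound 3 (1.47 log units; beyond the scatter) is large and involves the same place on the nitrogen. The step of an at least 16-fold lower number from compound 1 to compound 2 (1.22 log units; beyond the scatter) is also large, with trifluoromethyl in place of fluoro on an aromatic carbon. Within the data shown here, compound 4 carries neither fluoro nor trifluoromethyl, so neither step transfers directly, and its hydroxy-bearing group has no measured precedent. Its carbamoylamino arrangement, however, matches that of compound 1 and compound 2, so a move to a higher number is expected in this assay. The estimated change is a 3.6-fold higher number from compound 3 to compound 4 (0.56 log units; beyond the scatter), and its size is uncertain. Compound 4 is expected at 30000 nM, with an estimated range of 7000 nM to 150000 nM.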

Compound 4, half-maximal inhibitory concentration: 85000 nM
Compound 4: the middle estimate sits 2.8-fold (0.45 log units) below what was measured; the measured number falls inside the stated range.
By their numbers in this assay, from the lowest: compounds 3 and 2 (each within the scatter of the next); then compound 4. At a limit, above all of these: compound 1.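

In this assay, the exchange on the amide-type nitrogen gives a 10-fold higher number from compound 3 to compound 4 (1.01 log units; beyond the scatter), which shows that this position does not accept every group of this kind equally. Hydroxy in place of trifluoromethyl on an aromatic carbon gives a 5.7-fold higher number from compound 2 to compound 4 (0.75 log units; beyond the scatter), whereas hydroxy in place of fluoro on an aromatic carbon gives an at least 2.9-fold lower number from compound 1 to compound 4 (0.46 log units; beyond the scatter), so with the carbamoylamino arrangement kept, hydroxy sits between the other two substituents, and the substituent on the aromatic carbon alone moves the number in either direction. Compound 1 stands at a limit of the assay and not at a number, so the second of these steps gives only a bound on its size: the limit of >= 250000 nM in this assay, at which 1 of the 4 values shown sits.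

The compounds shown leave open whether an amine, a carboxylic acid or a methoxy group on the same aromatic carbon would fall in line with these three substituents. They also leave open whether hydroxy or fluoro would behave in the same way on the shorter arm of compound 3, where only trifluoromethyl appears.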